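Swapping the Aryl Group on the Carbonyl Carbon

The source may report more compounds than this note shows. Statements on the series, on what has been measured and on what is new or still open speak of the compounds shown alone.

Measured so far:
compound 1 `COc1ccc(-c2cc3ccccc3nc2/C=C/C(=O)c2ccc(O)cc2)cc1` gives 7440 nM
compound 2 `COc1ccc(-c2cc3ccccc3nc2/C=C/C(=O)c2ccc(OC)c(OC)c2)cc1` gives 8860 nM

Among the measured compounds shown here, in a functional assay on A549 cells (Homo sapiens) for antiproliferative activity, read by XTT assay, with a stated time of 72 h (on this read-out higher numbers stand for weaker inhibition and lower numbers for stronger inhibition), compound 2 stands at the highest of the two numbers, with compound 1 nearest; the one measured step is a 1.2-fold higher number from compound 1 to compound 2 (0.08 log units; within the scatter). Compound 3 `COc1ccc(-c2cc3ccccc3nc2/C=C/C(=O)c2sccc2N)cc1` differs from compound 2 by 3-aminothiophen-2-yl in place of 3,4-dimethoxyphenyl on a carbonyl carbon. That earlier step bears on this change because a 1.2-fold higher number from compound 1 to compound 2 (0.08 log units; within the scatter) also exchanged the group on the carbonyl carbon and stayed within the scatter. Compound 3 is therefore expected to show no step beyond the scatter, a 1.3-fold lower number from compound 2 to compound 3 (0.10 log units; within the scatter). Compound 3 is estimated at 7000 nM, within 2500 nM to 20000 nM.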

Compound 3, half-maximal inhibitory concentration: > 10000 nM
Compound 3: only a limit was reported; the forecaster's own chance of this, stated with the estimate: 15%; at least 1.4-fold (0.15 log units) between middle value and limit.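

In this assay compound 3 gives only a limit, > 10000 nM, the one result of this kind among the compounds shown: the limit of > 10000 nM in this assay, at which 1 of the 3 values shown sits. Read as floors, the steps are an at least 1.1-fold higher number from compound 2 to compound 3 (0.05 log units; that floor lies within the scatter) and an at least 1.3-fold higher number from compound 1 to compound 3 (0.12 log units; that floor lies within the scatter). Exchanging the group on the carbonyl carbon for 3-aminothiophen-2-yl therefore gives no measured size of change, and these floors do not settle whether the true steps exceed the scatter.

Going by these compounds, it remains open whether the amine or the thiophene ring matters more at this place. A thiophen-2-yl group without the amine and a 4-aminophenyl group would address that question.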